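Swapping the chlorophenyl arm of a GIP receptor binder

The compounds below may be only part of what the source reports. "The series", "measured", "known", "first", "only" and "open" are said of these compounds alone.

Measured compounds:
compound 1 `O=C(O)CCNC(=O)c1ccc(CC(c2ccc(Cl)cc2)c2nc(-c3ccc(C(F)(F)F)cc3)cs2)cc1` gives 211 nM
compound 2 `O=C(O)CCNC(=O)c1ccc(CN(c2ccc(Cl)cc2)c2nc(-c3ccc(C(F)(F)F)cc3)cs2)cc1` gives 410 nM

Both compounds were tested in an in vitro assay on BHK cells for binding affinity to gastric inhibitory polypeptide receptor (Homo sapiens); a lower number here means a stronger inhibitor, a higher number a weaker inhibitor. Compound 1 and compound 2 share a core and differ in how the chlorophenyl arm is attached; in this assay compound 2 gives 410 nM and compound 1 gives 211 nM. These two numbers sit within the usual scatter of each other, so on the evidence shown neither compound can be called the stronger binder, and compound 2 stands simply as one of two closely matched values.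

Compound 3 `Cc1cc(N(Cc2ccc(C(=O)NCCC(=O)O)cc2)c2nc(-c3ccc(C(F)(F)F)cc3)cs2)ccc1C(C)C` has not yet been measured in this assay. It is built from compound 2 by one change: 4-isopropyl-3-methylphenyl in place of 4-chlorophenyl on a nitrogen on an aromatic ring. Among the measured compounds shown here, there is no measured pair showing what this kind of replacement does, so the direction of any change is open. A step of modest size is expected, not clearly beyond the scatter in either direction, and the number for compound 3 is estimated at 500 nM, within a range from 150 nM to 1800 nM. This estimate means an expected step of a 1.2-fold higher number from compound 2 to compound 3 (0.09 log units; within the scatter).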

Compound 3, half-maximal inhibitory concentration: 293 nM
Estimate against measurement, compound 3: 1.7-fold (0.23 log units) above; the measured number falls inside the stated range.
By their numbers in this assay, from the lowest: compounds 1, 3 and 2 (each within the scatter of the next).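

The earlier compounds shown here gave no reading of what a change to the arm on this nitrogen does, and compound 3 provides the first one: putting 4-isopropyl-3-methylphenyl in place of 4-chlorophenyl gives a 1.4-fold lower number from compound 2 to compound 3 (0.15 log units; within the scatter) in this assay, a step that lies within the scatter. This position on the nitrogen therefore accepts an arm of 10 heavy atoms, all carbon, where compound 2 carries an arm of 7 heavy atoms that includes a chlorine, and the two numbers cannot be told apart in this assay. Nothing shown here bears on the reason for this result.

This single pair shows that one larger carbon-only arm is tolerated, but it cannot separate what the isopropyl and the methyl each contribute, and it gives no general rule for this position. Still open, going by these compounds, is how binding responds to other groups on this aromatic ring, such as a nitrile or an amine, or to a longer chain between the nitrogen and the ring.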